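The source may report more compounds than this note shows. Statements on the series, on what has been measured and on what is new or still open speak of the compounds shown alone.

Compound 1 `COc1cc(F)c(CN2C(=O)N(c3cc(OC)nc(OC)c3)S(=O)(=O)c3ccccc32)c(F)c1`: in an assay on isolated protein for displacement of a labelled ligand from Orexin/Hypocretin receptor type 1 (Homo sapiens), with a stated time of 90 min (on this read-out higher numbers stand for weaker inhibition and lower numbers for stronger inhibition), compound 1 gives 1 nM.
Compound 2 `COc1cc(F)c(CN2C(=O)N(c3ccc(OC)c(OC)c3)S(=O)(=O)c3ccccc32)c(F)c1`: in this assay compound 2 gives 2 nM.

On these two numbers compound 2 stands highest, yet the step of a 2.0-fold higher number from compound 1 to compound 2 (0.30 log units; within the scatter) lies within the scatter, so the two compounds cannot be told apart. Compound 3 `COc1cc(F)c(CN2C(=O)N(c3cnc(OC)c(OC)c3)S(=O)(=O)c3ccccc32)c(F)c1` arises from compound 2 by the change (5,6-dimethoxypyridin-3-yl in place of 3,4-dimethoxyphenyl on an amide-type nitrogen in a ring). Within the data shown here, the one measured step that bears on it, a 2.0-fold higher number from compound 1 to compound 2 (0.30 log units; within the scatter), exchanged a dimethoxypyridinyl for a dimethoxyphenyl on the same amide-type nitrogen and stayed within the scatter. Returning to a dimethoxypyridinyl is therefore expected to give no step beyond the scatter in this assay. The estimated step is no change at the digits printed from compound 2 to compound 3 (within the scatter). Compound 3 is expected to give 2 nM, with a range from 0.7 nM to 6 nM.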

Compound 3, inhibition constant: 2.51 nM
Beside the measured number, compound 3's estimate is 1.3-fold (0.10 log units) below it, within the range that was stated.
By their numbers in this assay, from the lowest: compounds 1, 2 and 3 (each within the scatter of the next, the first and the last beyond it).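

With 5,6-dimethoxypyridin-3-yl in place of 3,4-dimethoxyphenyl on the amide-type nitrogen, this assay shows a 1.3-fold higher number from compound 2 to compound 3 (0.10 log units; within the scatter) and so cannot tell these two groups apart. Set against the 2,6-dimethoxypyridin-4-yl group, the same group gives a 2.5-fold higher number from compound 1 to compound 3 (0.40 log units; beyond the scatter) as the only step here beyond the scatter, so the two dimethoxypyridinyl groups can be told apart, though only modestly. Nothing available explains this difference.

Going by these compounds, what an amine or a carboxylic acid in place of the methoxy groups would do at this position stays open.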